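Acetylation of the ring hydroxyl in a lactone series

The compounds below may be only part of what the source reports. "The series", "measured", "known", "first", "only" and "open" are said of these compounds alone.

Measured compounds:
- compound 1, `CCCC[C@@H](/C=C\[C@@H]1OC(=O)C=C[C@@H]1O)OC(C)=O`: 3.2 ug/mL
- compound 2, `CCCC[C@@H](/C=C\[C@@H]1OC(=O)C[C@@H](OC)[C@@H]1O)OC(C)=O`: > 20 ug/mL
- compound 3, `CC(=O)O[C@H](/C=C\[C@H]1CC=CC(=O)O1)C[C@@H](OC(C)=O)[C@H](C)OC(C)=O`: 4.5 ug/mL

In a functional assay on KB-V1 cells (Homo sapiens) for cytotoxicity, read by sulforhodamine B assay, with a stated time of 72 h (on this read-out lower numbers stand for an effect already at smaller amounts and higher numbers for an effect only at larger amounts of compound), compound 1 gives 3.2 ug/mL, the lowest of the two numbers recorded. Compound 3 sits nearest to it, with 4.5 ug/mL in this assay, a difference that lies within the scatter, so the two cannot be ordered. For compound 2 this assay reports only a limit, > 20 ug/mL, and no number; this is the limit of > 20 ug/mL in this assay, at which 1 of the 3 values shown sits.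

The unmeasured compound 4, `CCCC[C@@H](/C=C\[C@@H]1OC(=O)C=C[C@@H]1OC(C)=O)OC(C)=O`, is compound 1 with one change: acetyl in place of hydrogen on an oxygen on a saturated carbon. For the measured compounds named here, no step between measured compounds in this assay follows the same change, so nothing recorded sets its size. The closest comparison, compound 1 against compound 3, shows two acetylated compounds at numbers within the scatter of each other, which argues against a large move. The step from compound 1 to compound 4 is therefore expected to be small, a 1.1-fold higher number from compound 1 to compound 4 (0.04 log units; within the scatter), in no preferred direction beyond the scatter. Compound 4 is estimated at 3.5 ug/mL in this assay, with a range from 1.2 ug/mL to 10 ug/mL.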

Compound 4, concentration for half-maximal effect: 1.8 ug/mL
Compound 4: the middle estimate sits 1.9-fold (0.29 log units) above what was measured, and the stated range covers the measured number.
By their numbers in this assay, from the lowest: compounds 4, 1 and 3 (each within the scatter of the next, the first and the last beyond it). At a limit, above all of these: compound 2.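

In this assay the change from hydroxy to acetoxy gives a 1.8-fold lower number from compound 1 to compound 4 (0.25 log units; within the scatter) and no order of the two compounds can be read from it. For the compounds shown here, this is the first direct reading at this position: the free hydroxy on this saturated ring carbon is not needed to keep a number of this size, and the position accepts acetyl with its 3 heavy atoms. Nothing recorded here bears on the reason for the size of this step.

Going by these compounds, whether the position accepts more than acetyl stays open, as a longer chain such as butanoyl, a benzoyl group or an amine in place of the oxygen would show. On these data alone, the same change also rests on this single pair, and its size on any other core remains unknown.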